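This account rests on a few compounds, and the source may have more. Where it says the series, first, only, none or still open, it means among the compounds named here.

Measured in a functional assay on PC-3 cells (Homo sapiens) for cytotoxicity, read by MTT assay, with a stated time of 48 h; on this read-out higher numbers stand for weaker inhibition and lower numbers for stronger inhibition:
- Compound 1 `N#Cc1ccc(Cn2c(/C=C3\SC(=S)N(CC(=O)O)C3=O)nc3ccccc32)cc1`: 14400 nM
- Compound 2 `O=C(O)CN1C(=O)/C(=C/c2nc3ccccc3n2Cc2ccccc2)SC1=S`: 10800 nM

Among the measured compounds shown here, these two values lie within the scatter of each other, so compound 1 has no clear rank on the numbers so far. For the measured compounds named here, both are the only reference points for compound 3 `O=C(O)CN1C(=O)/C(=C/c2nc3ccccc3n2Cc2ccc(Cl)cc2)SC1=S`, which has not yet been measured. Going from compound 1 to compound 3 puts chloro in place of cyano on an aromatic carbon, para to a large group (chloro in place of cyano on an aromatic carbon). Going by the values given here, only one measured step touches this group: a 1.3-fold lower number from compound 1 to compound 2 (0.12 log units; within the scatter). It puts hydrogen in place of cyano and stays within the scatter. On that evidence, no change beyond the scatter is expected in this assay, and the estimated step is small: a 1.3-fold lower number from compound 1 to compound 3 (0.12 log units; within the scatter). Compound 3 is expected at 11000 nM, with an estimated range of 5500 nM to 22000 nM.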

Compound 3, half-maximal inhibitory concentration: 9670 nM
Compound 3: middle estimate off by 1.1-fold (0.06 log units), on the high side; the measured number falls inside the stated range.
By their numbers in this assay, from the lowest: compounds 3, 2 and 1 (each within the scatter of the next).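

In this assay, the carbon para to a large group now carries a third kind of substituent: chloro can stand in place of cyano (a 1.5-fold lower number from compound 1 to compound 3 (0.17 log units; within the scatter)) or in place of hydrogen (a 1.1-fold lower number from compound 2 to compound 3 (0.05 log units; within the scatter)), and both steps stay within the scatter. Compound 1, compound 2 and compound 3 therefore cannot be told apart, so cyano, hydrogen and chloro at this one position have not yet produced a real difference in this cell test. No measurement here explains this result or links it to any property of these groups.

From the compounds shown here alone, whether an amine or a longer chain at this carbon would move the number beyond the scatter remains open. So does whether chloro on a different carbon of the same ring would behave the same way.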